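A few compounds are considered here, and "the series" means these few. Any claim that something is new, unique, unknown or untested is made for them only; others in the source may bear on it.

Working notes on the series. All three measured compounds share one core and differ only in the aryl group on the carbonyl carbon. In a functional assay on HCT-15 cells (Homo sapiens) for cytotoxicity, read by sulforhodamine B assay, with a stated time of 48 h, tested at 1 uM (a higher number here means a weaker effect of the compound at the concentration tested, a lower number a stronger effect), compound 1 `COc1cc(-c2cc(/C=C/C(=O)c3ccc(N)cc3)[nH]n2)cc(OC)c1OC` gives 60%. Compound 2 `COc1cc(-c2cc(/C=C/C(=O)c3ccc(Cl)c(Cl)c3)[nH]n2)cc(OC)c1OC` gives 86%, and compound 3 `COc1ccc(C(=O)/C=C/c2cc(-c3cc(OC)c(OC)c(OC)c3)n[nH]2)cc1OC` gives 65%. Compound 3 thus stands second highest of the three: its gap to compound 1 lies within the scatter, whereas the step of a number 21 percentage points lower from compound 2 to compound 3 (beyond the scatter) lies beyond it. The step of a number 26 percentage points higher from compound 1 to compound 2 (beyond the scatter) points the same way, and a number 5 percentage points higher from compound 1 to compound 3 (within the scatter) adds nothing beyond the scatter.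

Compound 4 `COc1cc(-c2cc(/C=C/C(=O)c3ccc(F)c(F)c3)[nH]n2)cc(OC)c1OC` is the next point: 3,4-difluorophenyl in place of 3,4-dimethoxyphenyl on a carbonyl carbon. The step bearing most directly on it is a number 21 percentage points lower from compound 2 to compound 3 (beyond the scatter), which, read in reverse, puts a 3,4-dichlorophenyl ring at the weaker end. Going by the values given here, no measured pair contrasts fluorine with chlorine, so the size cannot be fixed closely. A step upward of a number 13 percentage points higher from compound 3 to compound 4 (beyond the scatter) is expected, somewhat smaller than the chlorine case. Compound 4 is therefore estimated at 78%, in the range 62% to 92%.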

Compound 4, a percentage reported as activity, at one concentration (the size of the read-out at that concentration, not a potency): 88%
For compound 4 the middle estimate is 10 percentage points below the measured one; the range from low to high includes it.
By their numbers in this assay, from the lowest: compounds 1 and 3 (each within the scatter of the next); then compounds 2 and 4 (each within the scatter of the next).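

With 3,4-difluorophenyl on the carbonyl carbon, this assay shows a number 23 percentage points higher from compound 3 to compound 4 (beyond the scatter) and a number 28 percentage points higher from compound 1 to compound 4 (beyond the scatter), so a second ring besides the 3,4-dichlorophenyl of compound 2 now gives a weaker effect than the 3,4-dimethoxyphenyl and 4-aminophenyl rings. The first direct contrast of fluorine with chlorine at this position gives a number 2 percentage points higher from compound 2 to compound 4 (within the scatter), and the two rings cannot be told apart at this concentration. Among the four compounds the position therefore splits into two groups, compounds 1 and 3 on one side and compounds 2 and 4 on the other, with no compound going against this split.

On these data alone, how a nitrile, a trifluoromethyl group or a carboxylic acid on this aryl ring would read remains open. No measurement available here explains the split between the two groups.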